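Pyrrole to methylpiperazine on the chain: compound 4

The source may report more compounds than this note shows. Statements on the series, on what has been measured and on what is new or still open speak of the compounds shown alone.

In a functional assay on ECa-109 cells (Homo sapiens) for antiproliferative activity, read by MTT assay, with a stated time of 48 h (on this read-out higher numbers stand for weaker inhibition and lower numbers for stronger inhibition), the compounds read:
- compound 1 `Cn1cc(C2=C(c3nn(CCCn4cncn4)c4ncccc34)C(=O)N(c3ccccc3)C2=O)c2ccccc21` gives > 100000 nM (a limit)
- compound 2 `Cn1cc(C2=C(c3nn(CCCN4CCCCC4)c4ncccc34)C(=O)N(c3ccccc3)C2=O)c2ccccc21` gives 12300 nM
- compound 3 `Cn1cc(C2=C(c3nn(CCCn4cccc4)c4ncccc34)C(=O)NC2=O)c2ccccc21` gives > 100000 nM (a limit)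

Compound 3 has only a limit and no number, and stands at the limit of > 100000 nM in this assay, at which 2 of the 3 values shown sit (with compound 1). Compound 4 `CN1CCN(CCCn2nc(C3=C(c4cn(C)c5ccccc45)C(=O)NC3=O)c3cccnc32)CC1` carries 4-methylpiperazin-1-yl in place of 1H-pyrrol-1-yl on a saturated chain carbon, three bonds along the chain from an aromatic nitrogen (4-methylpiperazin-1-yl in place of 1H-pyrrol-1-yl on a saturated chain carbon). Within the data shown here, the one measured step that bears on this is an at least 8.1-fold lower number from compound 1 to compound 2 (0.91 log units; beyond the scatter), a change at the same place, from an aromatic ring to a six-membered non-aromatic ring. It was measured on the core of compound 1, which differs from that of compound 3. A step of similar size towards stronger inhibition is therefore expected. The expected step is an at least 6.6-fold lower number from compound 3 to compound 4 (0.82 log units; beyond the scatter) in this assay overall. For compound 4 the estimated value is 15000 nM, with an expected range from 4000 nM to 70000 nM.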

Compound 4, half-maximal inhibitory concentration: > 100000 nM
Compound 4 gave a limit, no number (the forecaster's own chance of this, stated with the estimate: 20%); at least 6.6-fold (0.82 log units) between middle value and limit.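

Compound 3 and compound 4 both give only a limit, so no step can be read between them: the limit of > 100000 nM in this assay, at which 3 of the 4 values shown sit.

On these data alone, whether 4-methylpiperazin-1-yl in place of 1H-pyrrol-1-yl changes inhibition on the core of compound 3 stays open.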